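A Third Methoxy Group on the Shared Core

The source may report more compounds than this note shows. Statements on the series, on what has been measured and on what is new or still open speak of the compounds shown alone.

Of the compounds shown here, three have so far been measured in a functional assay on DU-145 cells (Homo sapiens) for antiproliferative activity, read by MTT assay, with a stated time of 48 h; a higher number here means a weaker inhibitor, a lower number a stronger inhibitor. Compound 1 `c1ccc(-c2nnc(-c3cn4ccccc4n3)o2)cc1` gives 23400 nM. Compound 2 `COc1ccc(-c2nnc(-c3cn4ccccc4n3)o2)cc1` differs from compound 1 by one change, (methoxy in place of hydrogen on an aromatic carbon), and in this assay compound 2 gives 12900 nM; the step of a 1.8-fold lower number from compound 1 to compound 2 (0.26 log units; within the scatter). Compound 3 `COc1ccc(-c2nnc(-c3cn4cccc(C)c4n3)o2)cc1OC` differs from compound 1 in more than one place, and the difference between the two cores is not broken down here. In this assay compound 3 gives 11800 nM.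

Compound 4 `COc1cc(-c2nnc(-c3cn4cccc(C)c4n3)o2)cc(OC)c1OC` has not yet been measured. It differs from compound 3 by methoxy in place of hydrogen on an aromatic carbon. Going by the values given here, this is the same kind of change as the one from compound 1 to compound 2, but not the same: in compound 2 the new group sits para to a large group, whereas in compound 4 it sits ortho to a methoxy group, meta to a large group and meta to a methoxy group. The step expected here is a 1.5-fold lower number from compound 3 to compound 4 (0.17 log units; within the scatter), because the earlier step of a 1.8-fold lower number from compound 1 to compound 2 (0.26 log units; within the scatter) stayed within the scatter. Compound 4 is therefore estimated to give 8000 nM in this assay, with a likely range from 3000 nM to 25000 nM.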

Compound 4, half-maximal inhibitory concentration: 11200 nM
Beside the measured number, compound 4's estimate is 1.4-fold (0.15 log units) below it; the measured number falls inside the stated range.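

In this assay, methoxy in place of hydrogen goes with a 1.1-fold lower number from compound 3 to compound 4 (0.02 log units; within the scatter), so the third methoxy group leaves the number of compound 4 indistinguishable from that of compound 3. Set beside the earlier step, the same change cannot be told apart between the two cores: the same change on two cores in this assay, a 1.8-fold lower number (0.26 log units; within the scatter) from compound 1 to compound 2 and a 1.1-fold lower number (0.02 log units; within the scatter) from compound 3 to compound 4, 1.7-fold (0.24 log units) apart, within the scatter of two such steps. This shows that the change carries across these two cores without a detectable difference in this assay, but it does not show that the methoxy group has a real effect on either core, since neither step stands clear of the scatter, and two pairs with the group in different surroundings are too few for a rule about the series.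

The compounds shown leave open whether a different group at this place on the ring, such as an amine, a carboxylic acid or a longer chain, would shift the number beyond the scatter. They also leave open whether the methoxy change would read the same way on a third core.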